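Sulfonyl aryl variation on a shared thione core

The source may hold more compounds than are shown below. What is called first, only, known or untested is meant among the compounds shown, and "the series" means these compounds.

Measured compounds:
compound 1 `Cc1cc(C)c(S(=O)(=O)NC2=NCCN2C(=S)SN2CCn3c2nsc3=S)c(C)c1`: >= 20000 nM
compound 2 `O=S(=O)(NC1=NCCN1C(=S)SN1CCn2c1nsc2=S)c1ccc(C(F)(F)F)cc1`: >= 20000 nM

In a functional assay on KYSE-510 cells (Homo sapiens) for antiproliferative activity, read by crystal violet staining, with a stated time of 96 h (on this read-out lower numbers stand for stronger inhibition of growth and higher numbers for weaker inhibition of growth), compound 1 gives >= 20000 nM, which is a limit of the assay and not a number. Compound 2 likewise gives only a limit in this assay, >= 20000 nM. Among the measured compounds shown here, the single measured step, a step that the two limits leave unreadable from compound 1 to compound 2, lies between two limits and cannot be read. Compound 2 therefore stands at the limit shared by both measured values, (the limit of >= 20000 nM in this assay, at which 2 of the 2 values shown sit). Compound 3 `COc1ccc(S(=O)(=O)NC2=NCCN2C(=S)SN2CCn3c2nsc3=S)cc1OC` carries the change (3,4-dimethoxyphenyl in place of 4-(trifluoromethyl)phenyl on a sulfonyl sulfur). For the measured compounds named here, no measured step resolves a change of this kind, so no movement beyond the scatter can be expected in either direction. Compound 3 is estimated at 20000 nM, within 8000 nM to 60000 nM, most probably again a limit. The expected step of a number no higher from compound 2 to compound 3 (the limit leaves the size open) is thus none beyond the scatter.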

Compound 3, concentration for 50% growth inhibition: >= 20000 nM
Compound 3 gave a limit, no number; the forecaster's own chance of this, stated with the estimate: 80%; the middle value lies on the limit itself.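

Among the compounds shown here, compound 3 gives >= 20000 nM, a limit of the assay and not a number, so no new step from compound 1 or compound 2 to compound 3 can be read. The compounds shown leave open whether any aryl group on the sulfonyl sulfur of the shared core gives a measurable value.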